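Working notes: methyl added to compound 2

The source may hold more compounds than are shown below. What is called first, only, known or untested is meant among the compounds shown, and "the series" means these compounds.

Measured so far in a functional assay on KB cells (Homo sapiens) for antiproliferative activity, read by sulforhodamine B assay, with a stated time of 3 days; on this read-out lower numbers stand for an effect already at smaller amounts and higher numbers for an effect only at larger amounts of compound:
- compound 1, `CCOc1ccc(-c2cc(=O)c3c(o2)C(CC)(CC)C(=O)C(CC)=C3O)cc1`: compound 1 gives > 52.4 uM, which is a limit of this assay and not a number.
- compound 2, `CCC1=C(O)c2c(oc(-c3ccccc3C)cc2=O)C(CC)(CC)C1=O`: compound 2 gives 40.9 uM.
- compound 3, `CCC1=C(O)c2c(oc(-c3ccccc3C(F)(F)F)cc2=O)C(CC)(CC)C1=O`: compound 3 gives 45.6 uM.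

Within the data shown here, compound 2 carries the only numbers here together with compound 3, and the two sit within the scatter of each other. The step of an at least 1.2-fold lower number from compound 1 to compound 2 (0.10 log units; that floor lies within the scatter) rests on the limit of > 52.4 uM in this assay, at which 1 of the 3 values shown sits, and so gives only a floor. The step of a 1.1-fold higher number from compound 2 to compound 3 (0.05 log units; within the scatter) is within the scatter.

Compound 4 is `CCC1=C(O)c2c(oc(-c3cc(C)ccc3C)cc2=O)C(CC)(CC)C1=O`. It differs from compound 2 by methyl in place of hydrogen on an aromatic carbon. Among the measured compounds shown here, neither measured step touches this position, and the one change of a substituent on that ring, a 1.1-fold higher number from compound 2 to compound 3 (0.05 log units; within the scatter), stayed within the scatter. No step beyond the scatter is therefore expected in this assay. The estimate for compound 4 is 38 uM, with a range from 18 uM to 80 uM. The expected step of a 1.1-fold lower number from compound 2 to compound 4 (0.03 log units; within the scatter) lies within the scatter.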

Compound 4, concentration for half-maximal effect: 14.5 uM
The estimate for compound 4 lay 2.6-fold (0.42 log units) above the measured number; measured number outside the range, below it.
By their numbers in this assay, from the lowest: compound 4; then compounds 2 and 3 (each within the scatter of the next). At a limit, above all of these: compound 1.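

In this assay, the added methyl, meta to a large group and para to a methyl group, gives a step beyond the scatter, a 2.8-fold lower number from compound 2 to compound 4 (0.45 log units; beyond the scatter), whereas the earlier change on this ring, a 1.1-fold higher number from compound 2 to compound 3 (0.05 log units; within the scatter), stayed within it; a ring position that carried only hydrogen therefore moves the number in this small set. The step of an at least 3.6-fold lower number from compound 1 to compound 4 (0.55 log units; beyond the scatter) is only a floor. Compound 1 stands at a limit of the assay and not a number: the limit of > 52.4 uM in this assay, at which 1 of the 4 values shown sits.

As far as these compounds go, whether this shift is specific to methyl remains open: a chlorine, a methoxy group, an amine or a carboxylic acid at the same position would test that. Also open, from the compounds shown here alone, is whether the same methyl would shift the number when trifluoromethyl stands in place of the other methyl, as in compound 3.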